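The compounds below may be only part of what the source reports. "The series", "measured", "known", "first", "only" and "open" are said of these compounds alone.

Compound 2, `Nc1cc(Oc2ccc(NC(=O)Nc3cccc(C(F)(F)F)c3)cc2)ncn1`, is the starting point here. In an assay on isolated protein for inhibition of serine/threonine-protein kinase TNNI3K (Homo sapiens) (on this read-out lower numbers stand for stronger inhibition and higher numbers for weaker inhibition), compound 2 gives 25 nM. Two other compounds give a sense of where that number sits. Compound 3, `CNc1cc(Oc2ccc(NC(=O)Nc3cccc(C(F)(F)F)c3)cc2Cl)ncn1`, gives 50 nM in this assay, a gap from compound 2 that lies within the usual scatter, so the two cannot be told apart on this read-out. Compound 1, `CNc1cc(Oc2ccc(NC(=O)Nc3cccc(CF)c3)cc2)ncn1`, gives 400 nM in this assay, a clearly higher number than compound 2 and well beyond the scatter. Compound 1 and compound 3 each differ from compound 2 in more than one place, so neither isolates a single change.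

Compound 4, `CC(=O)Nc1cc(Oc2ccc(NC(=O)Nc3cccc(C(F)(F)F)c3)cc2)ncn1`, is not yet measured. It differs from compound 2 in one place: acetyl in place of hydrogen on a nitrogen on an aromatic ring. Within the data shown here, no pair of measured compounds differs by exactly this change, so there is no direct precedent to lean on. As an expectation only, the step is estimated as a moderate rise in the number, a 3.2-fold higher number from compound 2 to compound 4 (0.51 log units; beyond the scatter), since nothing measured speaks for a gain here. Compound 4 is therefore expected to give about 80 nM in this assay, with a likely range from 25 nM to 300 nM.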

Compound 4, half-maximal inhibitory concentration: 20 nM
The estimate for compound 4 lay 4.0-fold (0.60 log units) above the measured number; the measured number lies below the stated range.
By their numbers in this assay, from the lowest: compounds 4, 2 and 3 (each within the scatter of the next, the first and the last beyond it); then compound 1.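

In this assay, the step of a 1.3-fold lower number from compound 2 to compound 4 (0.10 log units; within the scatter) lies within the scatter, so compound 2 and compound 4 cannot be told apart on this read-out. Among these compounds, this is the first direct look at this position, since no two of the earlier compounds differed in only one place: on the nitrogen of the 6-aminopyrimidin-4-yl group, hydrogen can give way to acetyl, which brings 3 heavy atoms and a carbonyl, with no measurable loss of inhibition. Nothing measured here explains why the change from amino to acetamido leaves the number in place.

Going by these compounds, a single acyl group cannot show how much room this position allows, so it remains open whether a longer chain such as propanoyl or butanoyl, or a ring-bearing group such as benzoyl, would also leave the number unchanged. On these data alone, it is equally open how a sulfonamide on the same nitrogen, or an acetyl carrying a terminal amine or a carboxylic acid, would fare.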